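A few compounds are considered here, and "the series" means these few. Any claim that something is new, unique, unknown or untested is made for them only; others in the source may bear on it.

Compound 1 `CNS(=O)(=O)c1ccc(F)c2ncc(I)cc12`: > 200000 nM
Compound 2 `O=S(=O)(NCc1ccccc1)c1ccc(F)c2ncc(I)cc12`: > 200000 nM

Both compounds share one core and differ only in the group on the sulfonamide nitrogen. In an assay for inhibition of methylcytosine dioxygenase TET2 (Homo sapiens), read by mass spectrometry, with stated times of 30 min and 1 h (a higher number here means a weaker inhibitor, a lower number a stronger inhibitor), compound 1 gives > 200000 nM, which is a limit of the assay rather than a number. In this assay compound 2 likewise gives > 200000 nM, again a limit. The step that the two limits leave unreadable from compound 1 to compound 2 cannot be read, because of the limit of > 200000 nM in this assay, at which 2 of the 2 values shown sit. Compound 2 therefore stands at the limit, with no measured value beyond it. Compound 3 `COc1cccc(NS(=O)(=O)c2ccc(F)c3ncc(I)cc23)c1` carries 3-methoxyphenyl in place of benzyl on a sulfonamide nitrogen. Within the data shown here, the only measured step, a step that the two limits leave unreadable from compound 1 to compound 2, touches the same position but has no readable size, so it gives no direction. The expectation for compound 3 is that this assay once more reports a limit. The step that the limit leaves unreadable from compound 2 to compound 3 is expected to be none beyond the scatter. Compound 3 is estimated at 300000 nM, within 100000 nM to 1000000 nM.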

Compound 3, half-maximal inhibitory concentration: > 200000 nM
Compound 3 was reported as a limit (the forecaster's own chance of this, stated with the estimate: 85%); the middle value lies beyond the limit too.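

In this assay compound 3 gives > 200000 nM, again a limit and not a number. Its steps from compound 1 and compound 2 therefore cannot be read: the limit of > 200000 nM in this assay, at which 3 of the 3 values shown sit.

The compounds shown leave open how methyl, benzyl and 3-methoxyphenyl on the sulfonamide nitrogen rank against one another in this assay, and whether any group there gives a measurable value.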